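This account rests on a few compounds, and the source may have more. Where it says the series, first, only, none or still open, it means among the compounds named here.

Among the measured compounds shown here, compound 1 `C=CNCc1cc(-c2c(C(=O)NCC)noc2-c2cc(C(C)C)c(O)cc2O)on1` is the stronger of the two compounds measured so far in a functional assay on HCT-116 cells (Homo sapiens) for inhibition; on this read-out higher numbers stand for weaker inhibition and lower numbers for stronger inhibition: compound 1 gives 121 nM. For the measured compounds named here, its only measured neighbour, compound 2 `CCNC(=O)c1noc(-c2cc(C(C)C)c(O)cc2O)c1-c1cc(CN2CCN(C)CC2)no1`, gives 340 nM in this assay, and the single step recorded between them, a 2.8-fold higher number from compound 1 to compound 2 (0.45 log units; beyond the scatter), came from a swap of the group on a saturated chain carbon bound to an aromatic carbon. Compound 3 `CCNC(=O)c1noc(-c2cc(C(C)C)c(O)cc2O)c1-c1ccn(C)n1` takes a different direction from compound 1: 1-methyl-1H-pyrazol-3-yl in place of 3-((vinylamino)methyl)-1,2-oxazol-5-yl on an aromatic carbon. The step from compound 1 to compound 2 bears on this only loosely, since it altered the group carried by the oxazole arm rather than removing that arm altogether; it did show that changes in this part of the molecule can cost potency by a modest margin. With the hydrogen-bond donor of the vinylamino group gone and a smaller ring in its place, a modest weakening is expected for compound 3, as a 2.1-fold higher number from compound 1 to compound 3 (0.33 log units; beyond the scatter). In this assay compound 3 is therefore estimated at 260 nM, with a plausible range from 90 nM to 750 nM.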

Compound 3, half-maximal inhibitory concentration: 16 nM
The estimate for compound 3 lay 16-fold (1.21 log units) above the measured number, outside the stated range (below it).
By their numbers in this assay, from the lowest: compound 3; then compound 1; then compound 2.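

In this assay, the step at this aromatic carbon of the ring bearing the ethylcarbamoyl group is a 7.6-fold lower number from compound 1 to compound 3 (0.88 log units; beyond the scatter), so the 3-((vinylamino)methyl)-1,2-oxazol-5-yl group is not required for a low number here. The earlier step, a 2.8-fold higher number from compound 1 to compound 2 (0.45 log units; beyond the scatter), changed only the group on the chain of the oxazole arm and raised the number, whereas this one shows that replacing the whole arm with the smaller 1-methyl-1H-pyrazol-3-yl, which has no hydrogen-bond donor, can lower it. No measurement is available to explain this gain.

The change replaces the ring, removes the side chain and adds a ring methyl all at once, so the compounds shown cannot tell which of these accounts for the lower number. They also leave open how the number would respond to an unsubstituted 1H-pyrazol-3-yl, to an ethyl group in place of the pyrazole methyl, or to a plain 1,2-oxazol-5-yl without the vinylamino chain.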